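The compounds below may be only part of what the source reports. "The series", "measured", "known", "first", "only" and "open" are said of these compounds alone.

Measured so far:
- compound 1, `CCOc1cc(/C=C/C(=O)c2ccncc2)cc(OCC)c1OCC`: 92 nM
- compound 2, `COc1ccccc1/C=C/C(=O)c1ccncc1`: 570 nM
- compound 3, `CCOc1cc(/C=C/C(=O)c2ccncc2)cc(OC)c1OC`: 63 nM

Of the compounds shown here, three share the same core and have been tested in an assay on cell membranes for inhibition of cytochrome P450 1A1 (Homo sapiens), read by fluorescence, using microsomes, with a stated time of 10 min; on this read-out lower numbers stand for stronger inhibition and higher numbers for weaker inhibition. In this assay compound 3 gives 63 nM, and compound 1 gives 92 nM; these two numbers lie within the usual scatter of each other, so nothing separates them. Among the compounds with values here, compound 2, with its single methoxy group, gives 570 nM, a number well beyond the scatter from compound 3, so compound 2 is a clearly weaker inhibitor than compound 3. Compound 3 thus sits at the strong end of what has been seen, with compound 1 beside it.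

The next compound, compound 4, `COc1ccc(/C=C/C(=O)c2ccncc2)cc1OC`, has not been measured. It differs from compound 3 in one place: hydrogen in place of ethoxy on an aromatic carbon. Within the data shown here, no pair of measured compounds shows this exact change, so its effect is unknown. The move from three alkoxy groups toward fewer, as in compound 2 with 570 nM, went with a weaker number, so some loss is expected here, though compound 4 keeps two methoxy groups. Compound 4 is expected to give 180 nM in this assay, a step of a 2.9-fold higher number from compound 3 to compound 4 (0.46 log units; beyond the scatter), within the range 60 nM to 550 nM.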

Compound 4, half-maximal inhibitory concentration: 380 nM
Compound 4: middle estimate off by 2.1-fold (0.32 log units), on the low side; the measured number falls inside the stated range.
By their numbers in this assay, from the lowest: compounds 3 and 1 (each within the scatter of the next); then compounds 4 and 2 (each within the scatter of the next).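

Within the data shown here, compound 3 and compound 4 give the first clean single-place comparison. Among these compounds, only one thing changes between them: an ethoxy group on an aromatic carbon gives way to hydrogen. In this assay, this change gives a 6.0-fold higher number from compound 3 to compound 4 (0.78 log units; beyond the scatter), so inhibition clearly weakens and the group on this carbon matters, even with both methoxy groups still in place. Nothing measured here explains why the ethoxy group counts for this much.

Going by these compounds, the comparison sets only a group against a bare hydrogen, so it remains open whether the ethoxy group itself is needed or whether something else on this carbon would serve as well, such as a fluorine atom, an amine or a longer chain like butoxy. On these data alone, it also remains open whether the same swap would have a similar effect on a compound whose other groups differ, such as compound 1, where all three groups are ethoxy.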